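This account rests on a few compounds, and the source may have more. Where it says the series, first, only, none or still open, it means among the compounds named here.

Measured in a functional assay on A549 cells (Homo sapiens) for antiproliferative activity, read by MTT assay, with a stated time of 72 h; on this read-out higher numbers stand for weaker inhibition and lower numbers for stronger inhibition:
Compound 1 `COc1cc2ncnc(Nc3ccc(Cl)c(C(F)(F)F)c3)c2cc1OCCCCC(=O)Nc1ccc(S(N)(=O)=O)cc1`: 9270 nM
Compound 2 `COc1ccc(Nc2ncnc3cc(OC)c(OCCCCC(=O)Nc4ccc(S(N)(=O)=O)cc4)cc23)cc1OC`: > 40000 nM, a limit of the assay and not a number
Compound 3 `NS(=O)(=O)c1ccc(NC(=S)Nc2ccc3ncnc(Nc4ccc(F)c(Cl)c4)c3c2)cc1`: > 40000 nM, a limit of the assay and not a number

Compound 3 stands at the limit of this assay, so no number is known for it. The same limit is shared across the series: the limit of > 40000 nM in this assay, at which 2 of the 3 values shown sit. Only compound 1 gives a real number in this assay.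

The step to compound 4 `Cc1ccc(Nc2ncnc3ccc(NC(=S)Nc4ccc(S(N)(=O)=O)cc4)cc23)cc1` is 4-methylphenyl in place of 3-chloro-4-fluorophenyl on a nitrogen on an aromatic ring. Within the data shown here, the one measured step that exchanges the aryl group on the same nitrogen of the shared core is an at least 4.3-fold higher number from compound 1 to compound 2 (0.63 log units; beyond the scatter), which carried the number out to the limit; compound 1 and compound 2 carry a different chain on the core than compound 3 and compound 4, so that step bears only loosely on the present one. Among the measured compounds shown here, no step here shows an exchange at this nitrogen pulling a number down from the limit. Compound 4 is therefore expected to show no step beyond the scatter, a number no higher from compound 3 to compound 4 (the limit leaves the size open), and most likely to return another limit in this assay. Compound 4 is estimated at 40000 nM, with a range from 15000 nM to 90000 nM.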

Compound 4, half-maximal inhibitory concentration: 2840 nM
The estimate for compound 4 lay 14-fold (1.15 log units) above the measured number; the whole stated range lies above it.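

In this assay, 4-methylphenyl in place of 3-chloro-4-fluorophenyl on this nitrogen gives an at least 14-fold lower number from compound 3 to compound 4 (1.14 log units; beyond the scatter), so an exchange at this position can bring a compound down from the limit to a real number. The earlier exchange at the same nitrogen, on a different chain, ran the other way, with an at least 4.3-fold higher number from compound 1 to compound 2 (0.63 log units; beyond the scatter); the aryl group at this position therefore moves the read-out in either direction beyond the scatter, although the two steps do not share a chain and cannot be set against each other in size. Compound 3 is a limit and not a number, and the true size of the new step stays unknown because that limit is all there is for compound 3: the limit of > 40000 nM in this assay, at which 2 of the 4 values shown sit.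

The exchange removes chlorine and fluorine and adds a methyl group in a single change, so a plain phenyl or a 4-chlorophenyl on this nitrogen would be needed to tell which part carries the step. On these data alone, whether 4-methylphenyl has the same effect on the chain of compound 1, or whether a larger 4-ethylphenyl goes further, also stays open.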